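The compounds below may be only part of what the source reports. "The series", "measured", "known", "first", "only" and "open" are said of these compounds alone.

Compound 1 `Cc1c(Sc2ccc(Cl)cc2)c(=O)on1C(=O)N1CCCCC1`: 6 nM
Compound 2 `CCc1c(C)n(C(=O)N2CCCCC2)oc1=O`: 18 nM
Compound 3 `Cc1c(C(C)C)c(=O)on1C(=O)N1CCCCC1`: 2 nM

In an assay (strain Wistar) for inhibition of Hormone-sensitive lipase (Rattus norvegicus), read by spectrophotometry (on this read-out higher numbers stand for weaker inhibition and lower numbers for stronger inhibition), compound 3 stands with the lowest of the three numbers; compound 1 is nearest to it and compound 2 furthest away, both beyond the scatter. Compound 4 `Cc1c(C(C)(C)C)c(=O)on1C(=O)N1CCCCC1` differs from compound 3 by methyl in place of hydrogen on a saturated chain carbon bound to an aromatic carbon and two saturated chain carbons, which amounts to isopropyl becoming tert-butyl. Among the compounds with values here, only one measured step is of the same kind: a 9.0-fold lower number from compound 2 to compound 3 (0.95 log units; beyond the scatter), where a methyl was likewise added to a saturated chain carbon. That gain need not repeat when the chain is enlarged a second time, so the expected step of no change at the digits printed from compound 3 to compound 4 (within the scatter) is small, perhaps none beyond the scatter. Compound 4 is therefore estimated at 2 nM, within a range of 0.7 nM to 6 nM.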

Compound 4, half-maximal inhibitory concentration: 14 nM
Beside the measured number, compound 4's estimate is 7.0-fold (0.85 log units) below it; the measured number lies above the stated range.
By their numbers in this assay, from the lowest: compound 3; then compound 1; then compounds 4 and 2 (each within the scatter of the next).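

In this assay, adding a methyl at this saturated chain carbon does not always lower the number: isopropyl becoming tert-butyl gives a 7.0-fold higher number from compound 3 to compound 4 (0.85 log units; beyond the scatter), the opposite direction to a 9.0-fold lower number from compound 2 to compound 3 (0.95 log units; beyond the scatter). Tert-butyl in place of ethyl gives a 1.3-fold lower number from compound 2 to compound 4 (0.11 log units; within the scatter), so among these three groups only isopropyl stands apart, with the lower number. Nothing available explains why the direction reverses. Still open, as far as these compounds go, is where a cyclopropyl group or a longer chain such as n-propyl would fall at this position relative to isopropyl and tert-butyl.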